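The source may report more compounds than this note shows. Statements on the series, on what has been measured and on what is new or still open speak of the compounds shown alone.

The study measured three compounds in an ADME assay on BHK-21 cells (Mesocricetus auratus) for cytotoxicity, read by MTT assay, with a stated time of 96 h; a higher number here means that more compound is tolerated, a lower number that less compound is tolerated. Compound 1 `CN(C)CCCN(/N=N/c1cc(F)ccc1F)c1cccc(C(F)(F)F)c1` gives 54000 nM there. Compound 3 `Cc1ccc(/N=N/c2ccc(NCCCN(C)C)cc2)cc1` reaches only a limit of the assay, > 100000 nM. Compound 2 `O=[N+]([O-])c1ccc(/N=N/N2CCCC2)cc1` likewise returns a limit rather than a number, >= 100000 nM. Among the three values, compound 2 therefore stands at the limit of >= 100000 nM in this assay, at which 1 of the 3 values shown sits, while the other limit shown is the limit of > 100000 nM in this assay, at which 1 of the 3 values shown sits. Compound 4 `Brc1ccc(/N=N/N2CCCC2)cc1` is not yet measured; it differs from compound 2 by bromo in place of nitro on an aromatic carbon. Among the measured compounds shown here, no measured pair shares such a change, so the expected step is an at least 1.2-fold lower number from compound 2 to compound 4 (0.09 log units; that floor lies within the scatter), not beyond the usual scatter. Compound 4 is estimated at 80000 nM, between 30000 nM and 200000 nM, with a fair chance that the assay again returns only a limit.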

Compound 4, half-maximal cytotoxic concentration: > 100000 nM
Compound 4 was reported as a limit (the forecaster's own chance of this, stated with the estimate: 55%); middle value at least 1.2-fold (0.09 log units) away from the limit.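

Among the compounds shown here, compound 2 and compound 4 both return only limits in this assay, and no step between them can be read. The compounds shown leave open whether bromo in place of nitro changes the tolerated concentration at all.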